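Replacing Methylamino with Azetidin-1-yl in Compound 3

The compounds below may be only part of what the source reports. "The series", "measured", "known", "first", "only" and "open" are said of these compounds alone.

All values come from an ADME assay (liver) for metabolic stability, with Liver microsome (Homo sapiens) as the target, using microsomes (a lower number here means slower removal, a higher number faster removal of the compound), and stand as follows.
compound 1 `Cc1cnc(NC(=O)c2cc(Oc3cnc(C(=O)N(C)C)cn3)c3cc(C)oc3c2)cn1` gives < 8.5 mL/min/kg as a limit
compound 2 `CCN(C)C(=O)c1cnc(Oc2cc(C(=O)Nc3cnc(C)cn3)cc3oc(C)cc23)cn1` gives < 8 mL/min/kg as a limit
compound 3 `CNC(=O)c1cnc(Oc2cc(C(=O)Nc3cnc(C)cn3)cc3oc(C)cc23)cn1` gives 10.1 mL/min/kg as a number

Going by the values given here, compound 3 holds the only true number in this assay at 10.1 mL/min/kg here. The other two values are limits. Compound 4 `Cc1cnc(NC(=O)c2cc(Oc3cnc(C(=O)N4CCC4)cn3)c3cc(C)oc3c2)cn1` differs from compound 3 by azetidin-1-yl in place of methylamino on a carbonyl carbon. Among the compounds with values here, two measured steps bear on this change (an at least 1.1-fold higher number from compound 1 to compound 3 (0.07 log units; that floor lies within the scatter) and an at least 1.2-fold higher number from compound 2 to compound 3 (0.10 log units; that floor lies within the scatter)), and their floors lie within the scatter. Each of them puts hydrogen on the amide-type nitrogen, whereas compound 4 carries no hydrogen there. The third step (a step that the two limits leave unreadable from compound 1 to compound 2) cannot be read. A small move towards a lower number is therefore expected, not clearly beyond the scatter, and a limit may well be reported instead of a number. The step expected is small (a 1.3-fold lower number from compound 3 to compound 4 (0.10 log units; within the scatter)). The estimated value for compound 4 is 8 mL/min/kg (range 4.5 mL/min/kg to 14 mL/min/kg).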

Compound 4, clearance: < 9.3 mL/min/kg
Compound 4: only a limit was reported; the forecaster's own chance of this, stated with the estimate: 55%; the middle value is on the limit's open side.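

In this assay, azetidin-1-yl in place of methylamino on the carbonyl carbon gives an at least 1.0-fold lower number from compound 3 to compound 4 (0.03 log units; that floor lies within the scatter), so this change cannot be told apart from the scatter. Compound 4 is reported only as a limit, not as a number: the limit of < 9.3 mL/min/kg in this assay, at which 1 of the 4 values shown sits. Going by these compounds alone, the ring thus joins the open-chain dimethylamino and ethyl(methyl)amino amides of compound 1 and compound 2: all three have no hydrogen on the amide-type nitrogen and are reported as limits, while compound 3, which keeps that hydrogen, is the only one with a number, and the steps among the three limits cannot be read.

Going by these compounds, the true values of compound 1, compound 2 and compound 4 stay open, so these amides cannot be ranked against one another. Also open, on these data alone, is how a larger ring such as pyrrolidin-1-yl or morpholin-4-yl, or a primary amide, would read in this assay at this position.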